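The source may report more compounds than this note shows. Statements on the series, on what has been measured and on what is new or still open speak of the compounds shown alone.

In an ADME assay on BaF3 cells (Mus musculus) for inhibition, read by CellTiter-Glo, with a stated time of 72 h (on this read-out lower numbers stand for stronger inhibition of growth and higher numbers for weaker inhibition of growth), compound 1 (`Cc1ccc(NC(=O)c2cccc(C(F)(F)F)c2)cc1N1Cc2cnc(NC3CCCCC3)nc2N(C)C1=O`) gives 5220 nM and compound 2 (`Cc1ccc(NC(=O)c2cccc(C(F)(F)F)c2)cc1N1Cc2cnc(NC3CC3)nc2N(C)C1=O`) gives 5060 nM. Compound 3 (`Cc1ccc(NC(=O)c2ccc(CN3CCC(N(C)C)C3)c(C(F)(F)F)c2)cc1N1Cc2cnc(Nc3cnn(C)c3)nc2N(C)C1=O`), at 414 nM, has the lowest of the three numbers, beyond the scatter from both of the others. Compound 4 (`Cc1ccc(NC(=O)c2cccc(C(F)(F)F)c2)cc1N1Cc2cnc(Nc3cnn(C)c3)nc2N(C)C1=O`) differs from compound 3 in one place: hydrogen in place of (3-(dimethylamino)pyrrolidin-1-yl)methyl on an aromatic carbon. Hydrogen thus stands in place of (3-(dimethylamino)pyrrolidin-1-yl)methyl on an aromatic carbon, ortho to a trifluoromethyl group.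

Among the compounds with values here, no measured step covers this change directly. Within the data shown here, the only step available, a 1.0-fold lower number from compound 1 to compound 2 (0.01 log units; within the scatter), concerns a different place and stays within the scatter. Compound 1 and compound 2 also lack the departing group, but they differ from compound 3 in a second place as well, so their values give only a rough upper guide. With compound 2 at 5060 nM as that guide, a move to a higher number, beyond the scatter, is expected in this assay. The expected change is a 4.8-fold higher number from compound 3 to compound 4 (0.68 log units; beyond the scatter). For compound 4 the estimated value is 2000 nM, with an expected range from 600 nM to 7000 nM.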

Compound 4, concentration for 50% growth inhibition: 352 nM
Beside the measured number, compound 4's estimate is 5.7-fold (0.75 log units) above it; measured number below the stated range.
By their numbers in this assay, from the lowest: compounds 4 and 3 (each within the scatter of the next); then compounds 2 and 1 (each within the scatter of the next).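

In this assay the (3-(dimethylamino)pyrrolidin-1-yl)methyl group on the aromatic carbon ortho to a trifluoromethyl group can give way to hydrogen with a 1.2-fold lower number from compound 3 to compound 4 (0.07 log units; within the scatter) as the whole step, so at this position the departing group makes no difference beyond the scatter. The large steps lie at the other place: 1-methyl-1H-pyrazol-4-yl on the nitrogen gives a 14-fold lower number from compound 2 to compound 4 (1.16 log units; beyond the scatter) when it replaces cyclopropyl and a 15-fold lower number from compound 1 to compound 4 (1.17 log units; beyond the scatter) when it replaces cyclohexyl. Among these four compounds, the lower numbers therefore go with the 1-methyl-1H-pyrazol-4-yl group and not with the group on the aromatic carbon.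

No measured evidence here gives a reason for either result. From the compounds shown here alone, whether a carboxylic acid or a morpholine on the same aromatic carbon, or a phenyl group on the nitrogen, would leave the number unchanged remains open.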